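This account rests on a few compounds, and the source may have more. Where it says the series, first, only, none or still open, it means among the compounds named here.

Measured in a physicochemical assay for solubility, in phosphate buffer, measured as kinetic solubility; a higher number here means a more soluble compound, a lower number a less soluble compound:
- compound 1 `CC(C)C(CC1C(=O)NC(=O)N1C)c1ccc(-c2ccc3cccc(F)c3c2)[nH]c1=O`: 33600 nM
- compound 2 `Cc1cc(C(/C=C2\OC(=O)NC2=O)C(C)C)c(=O)[nH]c1-c1ccc2cccc(F)c2c1`: 35700 nM

For the measured compounds named here, only these two numbers are available for the series so far. Going by the values given here, compound 1 at 33600 nM and compound 2 at 35700 nM lie within the scatter of each other, so compound 1 stands level with the only other measured compound.

The next compound to be measured is compound 3 `CC(C)C(c1ccc(-c2ccc3cccc(F)c3c2)[nH]c1=O)C1SC(=O)NC1=O`. It carries 2,4-dioxo-1,3-thiazolidin-5-yl in place of (3-methyl-2,5-dioxoimidazolidin-4-yl)methyl on a saturated chain carbon bound to an aromatic carbon and a saturated chain carbon.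

Among the compounds with values here, no measured step between compounds that differ in one place exists, so the data offer no direct precedent for this change. The working expectation therefore rests on compound 1 at 33600 nM as the starting point, and the range is kept wide.

In this assay no step beyond the scatter is expected, and the estimated change is a 1.1-fold lower number from compound 1 to compound 3 (0.05 log units; within the scatter). The estimate for compound 3 is 30000 nM, with an expected range from 12000 nM to 75000 nM.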

Compound 3, solubility: 20100 nM
Estimate against measurement, compound 3: 1.5-fold (0.17 log units) above; measured number inside the range.
By their numbers in this assay, from the lowest: compounds 3, 1 and 2 (each within the scatter of the next).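

In this assay, the first step read at this position, on a saturated chain carbon bound to an aromatic carbon and a saturated chain carbon, is a 1.7-fold lower number from compound 1 to compound 3 (0.22 log units; within the scatter) and so stays inside the usual variation of the measurement. At this position in the core of compound 1, the read-out therefore tolerates 2,4-dioxo-1,3-thiazolidin-5-yl in place of (3-methyl-2,5-dioxoimidazolidin-4-yl)methyl, a change that brings in sulfur, loses one ring nitrogen and alters the hydrogen-bond acceptor count, without a step beyond the scatter. No supporting measurement bears on this step or ties it to any feature of either group.

From the compounds shown here alone, both groups in this pair are uncharged five-membered non-aromatic rings, so the effect of an amine or a carboxylic acid on the same carbon stays open, as does whether either would give a step beyond the scatter. One pair also leaves open whether a longer chain between this carbon and the ring, or the same exchange on another core, would behave the same way.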